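Compound 3 and the loss of one methoxy group

The source may hold more compounds than are shown below. What is called first, only, known or untested is meant among the compounds shown, and "the series" means these compounds.

The series shares the core of compound 1 `Cc1cccc(NS(=O)(=O)c2ccc(N3CCNC3=O)cc2)c1C`, which also appears in compound 2 `Cc1ccccc1NS(=O)(=O)c1ccc(N2CCNC2=O)cc1` and compound 3 `COc1cc(NS(=O)(=O)c2ccc(N3CCNC3=O)cc2)cc(OC)c1`. These three compounds carry methyl or methoxy groups on that shared core. In a functional assay on MCF7 cells (Homo sapiens) for antiproliferative activity, read by sulforhodamine B assay, with a stated time of 48 h (on this read-out higher numbers stand for weaker inhibition and lower numbers for stronger inhibition), compound 3 gives 170 nM, compound 1 gives 230 nM and compound 2 gives 280 nM. The value of compound 3 lies within the usual scatter of both other values, so these data set it apart from neither compound.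

The next comparison is compound 4 `COc1cccc(NS(=O)(=O)c2ccc(N3CCNC3=O)cc2)c1`, which differs from compound 3 by hydrogen in place of methoxy on an aromatic carbon. Within the data shown here, no measured step removes a methoxy group. The closest measured step is hydrogen in place of methyl on an aromatic carbon, and it amounts to a 1.2-fold higher number from compound 1 to compound 2 (0.09 log units; within the scatter). That single step involves a different group, so it offers only limited guidance. Even so, it gives no reason to expect a large move in this assay, and the close values of all three measured compounds point the same way. The expected step is a 1.2-fold higher number from compound 3 to compound 4 (0.09 log units; within the scatter), which means no change beyond the scatter. For compound 4 the estimated value is 210 nM, with an expected range of 110 nM to 400 nM.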

Compound 4, half-maximal inhibitory concentration: 120 nM
Compound 4: the middle estimate sits 1.8-fold (0.24 log units) above what was measured, and the stated range covers the measured number.
By their numbers in this assay, from the lowest: compounds 4, 3, 1 and 2 (each within the scatter of the next, the first and the last beyond it).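

Hydrogen in place of methoxy on this aromatic carbon, meta to a large group, gives a 1.4-fold lower number from compound 3 to compound 4 (0.15 log units; within the scatter) in this assay and so adds a direct methoxy-to-hydrogen step at this place: within this series the site carries either group with no change that these data can separate. Among these compounds, the comparison of whole rings on the sulfonamide nitrogen is less even: 3-methoxyphenyl in place of 2-methylphenyl gives a 2.3-fold lower number from compound 2 to compound 4 (0.37 log units; beyond the scatter) and is the first step to pass the scatter, though only modestly, whereas 3-methoxyphenyl in place of 2,3-dimethylphenyl gives a 1.9-fold lower number from compound 1 to compound 4 (0.28 log units; within the scatter) and so does not carry that separation over to compound 1. No supporting measurement accompanies these steps, and the numbers alone offer no account of them.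

Still open, from the compounds shown here alone, is how the value moves when the remaining methoxy group of compound 4 gives way to hydrogen. Equally open, going by these compounds, is whether this site accepts anything beyond hydrogen and methoxy, such as an amine, a carboxylic acid or a longer chain like ethoxy.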